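The compounds below may be only part of what the source reports. "The series", "measured", "known", "first", "only" and "open" are said of these compounds alone.

In a functional assay on MDA-MB-231 cells (Homo sapiens) for cytotoxicity, read by sulforhodamine B assay, with a stated time of 3 days (a higher number here means that more compound is needed for the effect, a lower number that less compound is needed), compound 1 `CCOCc1c(C)coc1-c1ccc2c(c1OC)CCCC2(C)C` gives 42.7 uM. For the measured compounds named here, compound 2 `Cc1coc(-c2ccc3c(c2O)CCCC3)c1C(=O)O` gives 73.5 uM, so the two numbers lie within the usual scatter of each other, and compound 1 stands level with the only other measured compound. Compound 3 `COC(=O)c1c(C)coc1-c1ccc2c(c1OC)CCCC2(C)C` carries methoxycarbonyl in place of ethoxymethyl on an aromatic carbon. Going by the values given here, no measured pair shows this change, so no step beyond the scatter is expected in this assay, and neither direction is favoured. The estimate means a 1.1-fold higher number from compound 1 to compound 3 (0.02 log units; within the scatter), an expected step within the scatter. The estimated value for compound 3 is 45 uM, with an expected range from 20 uM to 95 uM.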

Compound 3, concentration for half-maximal effect: 61 uM
For compound 3 the middle estimate is 1.4-fold (0.13 log units) below the measured one; measured number inside the range.
By their numbers in this assay, from the lowest: compounds 1, 3 and 2 (each within the scatter of the next).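

In this assay, for the compounds shown here, the change gives a 1.4-fold higher number from compound 1 to compound 3 (0.15 log units; within the scatter) and forms the first measured pair that differs in one place. On this aromatic carbon of the five-membered ring, methoxycarbonyl therefore stands in place of ethoxymethyl without a step beyond the scatter, even though it adds a double bond outside aromatic rings and a second hydrogen-bond acceptor. No measurement at hand accounts for this result. Going by these compounds, whether an amine or a longer chain at this place would also stay within the scatter remains open. So does whether this change behaves alike on a core other than that of compound 1.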